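Notes on a hexyloxy/cyclohexyl pair across two imidazolone cores

The compounds below may be only part of what the source reports. "The series", "measured", "known", "first", "only" and "open" are said of these compounds alone.

Measured so far in a functional assay on brain (Rattus norvegicus, strain Wistar) for inhibition; a lower number here means a stronger inhibitor, a higher number a weaker inhibitor:
compound 1, `CCCCCCOc1ccc(-c2c(C)[nH]c(=O)n2C)cc1`, gives 7300 nM
compound 2, `Cc1[nH]c(=O)n(C)c1-c1ccc(C2CCCCC2)cc1`, gives 10000 nM
compound 3, `CCCCCCOc1ccc(-c2c(C)[nH]c(=O)n2C2CCCCC2)cc1`, gives 8500 nM

Compound 2 differs from compound 1 by cyclohexyl in place of hexyloxy on an aromatic carbon, and the step is a 1.4-fold higher number from compound 1 to compound 2 (0.14 log units; within the scatter). Compound 3 differs from compound 1 by cyclohexyl in place of methyl on an aromatic nitrogen, with a step of a 1.2-fold higher number from compound 1 to compound 3 (0.07 log units; within the scatter); all three numbers therefore sit close together in this assay.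

Compound 4, `Cc1[nH]c(=O)n(C2CCCCC2)c1-c1ccc(C2CCCCC2)cc1`, has not been measured. It differs from compound 3 by cyclohexyl in place of hexyloxy on an aromatic carbon. This is the same kind of change as that from compound 1 to compound 2: in compound 3 the place is para to a large group, whereas in compound 1 it is para to a group of 8 heavy atoms.

Going by the values given here, compound 4 is expected to show a step of a 1.4-fold higher number from compound 3 to compound 4 (0.15 log units; within the scatter), set beside the measured 1.4-fold higher number from compound 1 to compound 2 (0.14 log units; within the scatter), because compound 3 itself gives 8500 nM and the only precedent for this change is small. Compound 4 is thus estimated at 12000 nM, with the expected range running from 5000 nM to 30000 nM.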

Compound 4, half-maximal inhibitory concentration: 28900 nM
Compound 4: the middle estimate sits 2.4-fold (0.38 log units) below what was measured; measured number inside the range.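

In this assay, cyclohexyl in place of hexyloxy on an aromatic carbon gives a 3.4-fold higher number from compound 3 to compound 4 (0.53 log units; beyond the scatter) and, set against the same change on the core of compound 1, the two steps do not separate: the same change on two cores in this assay, a 1.4-fold higher number (0.14 log units; within the scatter) from compound 1 to compound 2 and a 3.4-fold higher number (0.53 log units; beyond the scatter) from compound 3 to compound 4, 2.5-fold (0.39 log units) apart, within the scatter of two such steps
Cyclohexyl in place of methyl on an aromatic nitrogen gives a 2.9-fold higher number from compound 2 to compound 4 (0.46 log units; beyond the scatter) and, again, the two steps do not separate: the same change on two cores in this assay, a 1.2-fold higher number (0.07 log units; within the scatter) from compound 1 to compound 3 and a 2.9-fold higher number (0.46 log units; beyond the scatter) from compound 2 to compound 4, 2.5-fold (0.39 log units) apart, within the scatter of two such steps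
Going by these compounds alone, each change therefore carries from one core to the other within what two such steps can scatter, but this does not show that the steps are equal, since only one pair of steps stands behind each change and the newer step of each pair lies beyond the scatter while the earlier one lies within it.

From the compounds shown here alone, what the chain at this place can tolerate remains open, as only hexyloxy and cyclohexyl appear there. Going by these compounds, whether a shorter chain such as butoxy, an amine or a carboxylic acid in that place would follow the same steps remains unknown, as does the effect of an ethyl group on the aromatic nitrogen.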